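Amide aryl variation on a shared flavonol core

A few compounds are considered here, and "the series" means these few. Any claim that something is new, unique, unknown or untested is made for them only; others in the source may bear on it.

Measured so far:
compound 1 `COc1ccc(C(=O)Nc2cccc(-c3oc4cc(-c5ccc(F)cc5)ccc4c(=O)c3O)c2)cc1` gives 6250 nM
compound 2 `O=C(Nc1cccc(-c2oc3cc(-c4ccc(F)cc4)ccc3c(=O)c2O)c1)c1ccc(F)cc1F` gives 13500 nM
compound 3 `COc1cc(OC)cc(C(=O)Nc2cccc(-c3oc4cc(-c5ccc(F)cc5)ccc4c(=O)c3O)c2)c1` gives 3470 nM

All three were run in a functional assay on MCF7 cells (Homo sapiens) for antiproliferative activity, read by CCK-8 assay, with a stated time of 72 h; on this read-out lower numbers stand for stronger inhibition and higher numbers for weaker inhibition. Compound 3 has the lowest number of the three; its gap to compound 1 sits within the scatter, and only a 3.9-fold lower number from compound 2 to compound 3 (0.59 log units; beyond the scatter) lies beyond it. Compound 4 `Cc1cc(C)cc(C(=O)Nc2cccc(-c3oc4cc(-c5ccc(F)cc5)ccc4c(=O)c3O)c2)c1` differs by 3,5-dimethylphenyl in place of 3,5-dimethoxyphenyl on a carbonyl carbon. Among the compounds with values here, the steps that bear on this are the other aryl swaps on the same carbonyl carbon: a 1.8-fold lower number from compound 1 to compound 3 (0.26 log units; within the scatter), a 2.2-fold higher number from compound 1 to compound 2 (0.33 log units; beyond the scatter) and a 3.9-fold lower number from compound 2 to compound 3 (0.59 log units; beyond the scatter), all modest or within scatter. A step of similar size is therefore expected, most likely toward a higher number, as a 1.3-fold higher number from compound 3 to compound 4 (0.11 log units; within the scatter). Compound 4 is estimated at 4500 nM, within 1800 nM to 11000 nM.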

Compound 4, half-maximal inhibitory concentration: 20400 nM
Beside the measured number, compound 4's estimate is 4.5-fold (0.66 log units) below it, and the stated range ends below it.
By their numbers in this assay, from the lowest: compounds 3 and 1 (each within the scatter of the next); then compounds 2 and 4 (each within the scatter of the next).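

At this carbonyl carbon, 3,5-dimethylphenyl in place of 3,5-dimethoxyphenyl gives the largest step yet seen here (a 5.9-fold higher number from compound 3 to compound 4 (0.77 log units; beyond the scatter)). Compound 4 also stands apart from the 4-methoxyphenyl amide (a 3.3-fold higher number from compound 1 to compound 4 (0.51 log units; beyond the scatter)), but not from the 2,4-difluorophenyl amide (a 1.5-fold higher number from compound 2 to compound 4 (0.18 log units; within the scatter)). No supporting data are available to account for these steps.

As far as these compounds go, it remains open how 3,5-diethoxyphenyl or 3,5-dihydroxyphenyl would read at this place. A single 3-methoxyphenyl would test whether both methoxy groups are needed.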